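The source may report more compounds than this note shows. Statements on the series, on what has been measured and on what is new or still open speak of the compounds shown alone.

Compound 1 `CC(=O)OC(C)n1cnc2c(Cl)nc(N)nc21` — > 500000 nM
Compound 2 `CC(=O)OC(C)n1cnc2c(Cl)nc(I)nc21` — 15900 nM
Compound 3 `CC(=O)OC(C)n1cnc2c(Cl)nc(F)nc21` — 44000 nM

In a functional assay on CCRF-CEM cells (Homo sapiens) for inhibition (on this read-out lower numbers stand for stronger inhibition and higher numbers for weaker inhibition), compound 1 gives > 500000 nM, which is a limit of the assay rather than a number, as shown by the limit of > 500000 nM in this assay, at which 1 of the 3 values shown sits. Compound 2 and compound 3 give numbers: an at least 31-fold lower number from compound 1 to compound 2 (1.49 log units; beyond the scatter), and an at least 11-fold lower number from compound 1 to compound 3 (1.05 log units; beyond the scatter), so both halogen-bearing analogues inhibit these cells more strongly than the amino-bearing compound 1. Between the two halogens there is a smaller gap: a 2.8-fold higher number from compound 2 to compound 3 (0.44 log units; beyond the scatter).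

Compound 4 `CC(=O)OC(C)n1cnc2c(S)nc(N)nc21` keeps the amino group of compound 1 and changes a different position of the shared core: sulfanyl in place of chloro on an aromatic carbon. None of the three measured steps touches the chloro position; all of them swap the amino group for a halogen. Among the measured compounds shown here, they therefore give no direct guide to this change, and the only anchor is compound 1 at its limit. Without a comparable step, the expected outcome in this assay is uncertain in direction. The working estimate for compound 4 is 200000 nM, expected to lie between 10000 nM and 1000000 nM. This estimate means a step of an at least 2.5-fold lower number from compound 1 to compound 4 (0.39 log units; beyond the scatter), and a further limit-only result is also considered likely.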

Compound 4, half-maximal inhibitory concentration: 381000 nM
Compound 4: middle estimate off by 1.9-fold (0.28 log units), on the low side; measured number inside the range.
By their numbers in this assay, from the lowest: compound 2; then compound 3; then compound 4. At a limit, above all of these: compound 1.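

Compound 4 is the first compound shown in which the chloro group of the shared core is changed, and with the amino group kept it gives a measured number in this assay rather than a limit. Sulfanyl in place of chloro gives an at least 1.3-fold lower number from compound 1 to compound 4 (0.11 log units; that floor lies within the scatter), so the smallest gap this step allows does not separate the two compounds, while the true gap could be wider. The step has a one-sided reading, as compound 1 is a limit and not a number, and it is the only reference for this change: the limit of > 500000 nM in this assay, at which 1 of the 4 values shown sits.

The compounds shown leave open how this position responds to other groups, such as a methylthio group, a hydroxyl or an amine, any of which could stand in place of chloro while the rest of compound 1 stays the same. They also leave open whether sulfanyl at this position can be combined with iodo or fluoro in place of the amino group, the two swaps that gave compound 2 and compound 3 their lower numbers.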